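Cytotoxicity on Vero cells: trimming the methyl off the phenoxy group

This account rests on a few compounds, and the source may have more. Where it says the series, first, only, none or still open, it means among the compounds named here.

Measured so far:
Compound 1, `COc1cc2c(cc1OC)CN(S(=O)(=O)c1ccc(-n3cc(COc4ccc(C)cc4)nn3)cc1)CC2`, > 50 ug/mL
Compound 2, `COc1cc2c(cc1OC)CN(S(=O)(=O)c1ccc(-n3cc(COc4ccccc4C)nn3)cc1)CC2`, > 50 ug/mL

Compound 1 has the structure `COc1cc2c(cc1OC)CN(S(=O)(=O)c1ccc(-n3cc(COc4ccc(C)cc4)nn3)cc1)CC2`. In an ADME assay on Vero cells (Chlorocebus sabaeus) for cytotoxicity, with a stated time of 4 days (a lower number here means a stronger inhibitor, a higher number a weaker inhibitor), compound 1 gives only a limit of the assay, > 50 ug/mL. Compound 2, with the structure `COc1cc2c(cc1OC)CN(S(=O)(=O)c1ccc(-n3cc(COc4ccccc4C)nn3)cc1)CC2`, differs from it by a step that the two limits leave unreadable from compound 1 to compound 2. In this assay compound 2 also gives only a limit, > 50 ug/mL. Because both values sit at the limit of > 50 ug/mL in this assay, at which 2 of the 2 values shown sit, the size of that step cannot be read.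

Compound 3 has the structure `COc1cc2c(cc1OC)CN(S(=O)(=O)c1ccc(-n3cc(COc4ccccc4)nn3)cc1)CC2`. It differs from compound 2 by hydrogen in place of methyl on an aromatic carbon. Going by the values given here, only the step from compound 1 to compound 2 bears on it, and that step is unreadable. Given that both neighbours sit at the limit, compound 3 is expected to give a step that the limit leaves unreadable from compound 2 to compound 3 in this assay. Compound 3 is therefore estimated at 60 ug/mL, between 30 ug/mL and 150 ug/mL.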

Compound 3, half-maximal inhibitory concentration: > 50 ug/mL
Compound 3: a limit, no number (the forecaster's own chance of this, stated with the estimate: 85%); the middle value is on the limit's open side.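

Compound 3 also gives only a limit in this assay, so its steps from compound 1 and compound 2 cannot be read, because all three values sit at the same limit: the limit of > 50 ug/mL in this assay, at which 3 of the 3 values shown sit. Still open, as far as these compounds go, is where compound 1, compound 2 and compound 3 would reach half-maximal inhibition in this assay, and whether hydrogen in place of methyl changes that concentration.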